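A few compounds are considered here, and "the series" means these few. Any claim that something is new, unique, unknown or untested is made for them only; others in the source may bear on it.

Compound 1 `CC(=O)N1C[C@H]2CC[C@H](O[C@H](C)c3cc(C(F)(F)F)cc(C(F)(F)F)c3)[C@@H](c3ccc(F)cc3)[C@@H]2C1` gives 7.8 nM in an assay on CHO cells for displacement of a labelled ligand from Substance-P receptor (Homo sapiens), in the presence of a further agent that is not named here; on this read-out higher numbers stand for weaker inhibition and lower numbers for stronger inhibition.
Compound 2 `CC1=C(N2C[C@H]3CC[C@H](O[C@H](C)c4cc(C(F)(F)F)cc(C(F)(F)F)c4)[C@@H](c4ccc(F)cc4)[C@@H]3C2)CCC1=O` gives 11 nM in this assay.

On these two numbers compound 2 and compound 1 sit within the scatter of each other, so neither can be called stronger. Compound 3 `C[C@@H](O[C@H]1CC[C@@H]2CN(C3=CC(=O)CCC3)C[C@H]2[C@@H]1c1ccc(F)cc1)c1cc(C(F)(F)F)cc(C(F)(F)F)c1` differs from compound 2 in one place: 3-oxocyclohex-1-en-1-yl in place of 2-methyl-3-oxocyclopent-1-en-1-yl on an amine nitrogen in a ring. Going by the values given here, the only measured step at this nitrogen, a 1.4-fold higher number from compound 1 to compound 2 (0.15 log units; within the scatter), changed the whole substituent and still stayed within the scatter, which suggests that this part of the molecule tolerates change. Exchanging one oxocycloalkenyl ring for another is therefore expected to give a 1.1-fold lower number from compound 2 to compound 3 (0.04 log units; within the scatter), nothing beyond the scatter. Compound 3 is estimated at 10 nM, in the range 4 nM to 28 nM.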

Compound 3, half-maximal inhibitory concentration: 22 nM
Beside the measured number, compound 3's estimate is 2.2-fold (0.34 log units) below it; measured number inside the range.
By their numbers in this assay, from the lowest: compounds 1, 2 and 3 (each within the scatter of the next, the first and the last beyond it).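

Exchanging the ring in this assay gives a 2.0-fold higher number from compound 2 to compound 3 (0.30 log units; within the scatter) and so does not separate these two oxocycloalkenyl groups. Set against acetyl, however, the new group gives a 2.8-fold higher number from compound 1 to compound 3 (0.45 log units; beyond the scatter) and this modest step is the first at this nitrogen to pass beyond the scatter, so the tolerance seen earlier has a limit. Nothing available explains this difference.

Ring size and the methyl group change together between compound 2 and compound 3, leaving their separate contributions open. A plain 3-oxocyclopent-1-en-1-yl group would separate them, while a propanoyl chain would test how far the acetyl group can be extended.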